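Ortho substituent swap on the arylhydrazone series

The source may report more compounds than this note shows. Statements on the series, on what has been measured and on what is new or still open speak of the compounds shown alone.

Two compounds of the series have been taken through an assay on isolated protein for binding affinity to corticotropin-releasing factor receptor 1 (Homo sapiens) (a higher number here means a weaker inhibitor, a lower number a stronger inhibitor), so far. Compound 1 `CC(=O)/C(=N\Nc1ccccc1Cl)Sc1cccc(Cl)c1` sits at the limit of the assay, > 10000 nM being a limit rather than a number. Compound 2 `CSc1cccc(N/C(=N/Nc2ccccc2C)C(C)=O)c1` likewise returns only a limit, > 10000 nM. Both values therefore share the line (the limit of > 10000 nM in this assay, at which 2 of the 2 values shown sit), which gives no lower anchor for the potency of this pair.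

Compound 3 `CSc1cccc(N/C(=N/Nc2ccccc2Cl)C(C)=O)c1` differs from compound 2 by chloro in place of methyl on an aromatic carbon; read one bond further out, this is 2-methylphenyl to 2-chlorophenyl. For the measured compounds named here, no measured step shows what this exchange does in this assay. Since compound 2 stands only at a limit, no change beyond the scatter can be asserted in either direction, and compound 3 is expected to remain at or near the limit. The estimate for compound 3 is 15000 nM, spanning 5000 nM to 50000 nM, which amounts to an expected step that the limit leaves unreadable from compound 2 to compound 3.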

Compound 3, inhibition constant: > 10000 nM
Compound 3: only a limit was reported (the forecaster's own chance of this, stated with the estimate: 80%); the middle value does not contradict the limit.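

Compound 3 gives > 10000 nM, which is a limit and not a number; compound 2 also stands only at a limit, so no step can be read between compound 2 and compound 3. The compounds shown leave open what 2-methylphenyl to 2-chlorophenyl does in this assay, and which compound of the series, if any, gives a measured value.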